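A pyridin-3-yl group added to a weak adenosine binder

The source may hold more compounds than are shown below. What is called first, only, known or untested is meant among the compounds shown, and "the series" means these compounds.

Compound 1 `Cc1nn(C)c2c(O)ncnc12`: 20100 nM
Compound 2 `Cn1c(=O)c2nc(Cc3ccccc3)[nH]c2n(C)c1=O`: 1500 nM

In an assay on membranes from brain for binding affinity to adenosine receptor A1 (Rattus norvegicus), read by radioligand binding (a higher number here means a weaker inhibitor, a lower number a stronger inhibitor), compound 1 gives 20100 nM, the highest number of the two measured compounds, so it is the weaker inhibitor. Compound 2, which is built on a different core, gives 1500 nM in this assay, a gap that lies beyond the usual scatter. Compound 3 `Cc1nn(C)c2c(O)nc(-c3cccnc3)nc12` keeps the core of compound 1 and differs from it in one place: pyridin-3-yl in place of hydrogen on an aromatic carbon. For the measured compounds named here, no step between two measured compounds shows what this change does, so the expectation rests on the single value of compound 1 and on the change itself. A sizeable gain in binding is expected, that is a lower number, rather than no change. For compound 3 the expected step is a 6.7-fold lower number from compound 1 to compound 3 (0.83 log units; beyond the scatter) in this assay. Compound 3 is therefore estimated at 3000 nM, within a range from 500 nM to 15000 nM.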

Compound 3, half-maximal inhibitory concentration: 3090 nM
For compound 3 the middle estimate is 1.0-fold (0.01 log units) below the measured one; low and high end bracket the measured number.
By their numbers in this assay, from the lowest: compound 2; then compound 3; then compound 1.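

In this assay, the aromatic carbon between two ring nitrogen atoms proves open to change: pyridin-3-yl in place of hydrogen gives a 6.5-fold lower number from compound 1 to compound 3 (0.81 log units; beyond the scatter) and so a real, if modest, gain in binding. For the compounds shown here, this is the first measured step on the core of compound 1, and it shows that a six-membered aromatic ring can sit on this carbon without any loss of binding. Nothing in the data explains why binding improves.

On these data alone, with a single group at this carbon, it remains open whether the gain needs the ring nitrogen of pyridin-3-yl or whether any aromatic ring would serve. A phenyl ring, made of carbon alone, would test that question directly, while a small methyl group or an amine on the same carbon would show whether a ring is needed at all.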